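This account rests on a few compounds, and the source may have more. Where it says the series, first, only, none or still open, it means among the compounds named here.

Measured so far:
- compound 1 `C=C1CC[C@@H]2[C@](C)(CO[Si](C(C)C)(C(C)C)C(C)C)[C@H](O)CC[C@@]2(C)[C@@H]1C/C=C1/C(=O)OC[C@H]1O`: 2.88 uM
- compound 2 `C=C1CC[C@@H]2[C@](C)(COC(c3ccccc3)(c3ccccc3)c3ccccc3)[C@H](O)CC[C@@]2(C)[C@@H]1C/C=C1/C(=O)OC[C@H]1O`: 2.72 uM
- compound 3 `C=C1CC[C@@H]2[C@](C)(COC(c3ccccc3)(c3ccccc3)c3ccccc3)[C@H](OC(C)=O)CC[C@@]2(C)[C@@H]1C/C=C1/C(=O)OC[C@H]1OC(C)=O`: 22.7 uM

In a functional assay on MCF7 cells (Homo sapiens) for cytotoxicity, read by sulforhodamine B assay (a lower number here means that less compound is needed, a higher number that more compound is needed for the effect), compound 1 gives 2.88 uM and stands second highest of the three numbers. Its nearest neighbour is compound 2, which in this assay gives 2.72 uM, a gap within the scatter; no order between compound 1 and compound 2 can be read from these two values. Compound 3, with both secondary hydroxyls acetylated, gives 22.7 uM, a higher number than compound 1 beyond the scatter. Among the compounds with values here, no single-point step between measured compounds is available.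

Compound 4 `C=C1CC[C@@H]2[C@](C)(COC(C)=O)[C@H](O)CC[C@@]2(C)[C@@H]1C/C=C1/C(=O)OC[C@H]1O` differs from compound 1 by a group of 3 heavy atoms (2 carbon, 1 oxygen; no ring) in place of a group of 10 heavy atoms (9 carbon, 1 silicon; no ring), on an oxygen on a saturated carbon, the secondary hydroxyls being left free as in compound 1 and compound 2. Two different groups on that oxygen, in compound 1 and compound 2, give numbers within the scatter of each other, so a small group there is expected to change little. The expected step is a 1.4-fold higher number from compound 1 to compound 4 (0.14 log units; within the scatter), if anything toward a higher number, and likely not beyond the scatter. Compound 4 is expected at 4 uM, with a range from 1.5 uM to 12 uM.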

Compound 4, concentration for half-maximal effect: 18.3 uM
Compound 4: middle estimate off by 4.6-fold (0.66 log units), on the low side; measured number above the stated range.
By their numbers in this assay, from the lowest: compounds 2 and 1 (each within the scatter of the next); then compounds 4 and 3 (each within the scatter of the next).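

In this assay, the group on this oxygen on a saturated carbon does matter: acetyl in place of the group of 10 heavy atoms gives a 6.4-fold higher number from compound 1 to compound 4 (0.80 log units; beyond the scatter), with the secondary hydroxyls free in both compounds. The earlier pair could not show this, as the two groups in compound 1 and compound 2 gave values within the scatter of each other; compound 2 gives 2.72 uM, whereas compound 4 gives 18.3 uM. No measurement is available that bears on what lies behind the step.

Within the data shown here, with only three groups on this oxygen, it remains open which feature of these groups tracks the number. A free hydroxyl at this place, a methyl ether, or a longer ester such as benzoyl would help to separate the possible readings.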